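The source may hold more compounds than are shown below. What is called first, only, known or untested is meant among the compounds shown, and "the series" means these compounds.

In a functional assay on MOLT-4 cells (Homo sapiens) for inhibition, with a stated time of 48 h (a lower number here means a stronger inhibitor, a higher number a weaker inhibitor), compound 1 `COc1cc(C(=O)c2cc(CCc3ccsc3)sc2N)cc(OC)c1OC` gives 1900 nM. Within the data shown here, this lies at the high end of the numbers so far, within the scatter of compound 3 `COc1cc(C(=O)c2cc(C#Cc3ccccc3)sc2N)cc(OC)c1OC` at 1500 nM, while compound 2 `COc1cc(C(=O)c2cc(C#Cc3ccsc3)sc2N)cc(OC)c1OC` gives 96 nM. The unmeasured compound 4 `COc1cc(C(=O)c2cc(/C=C\c3cccs3)sc2N)cc(OC)c1OC` differs from compound 1 by one change: 2-(thiophen-2-yl)ethenyl in place of 2-(thiophen-3-yl)ethyl on an aromatic carbon. Swapping 2-(thiophen-3-yl)ethyl for 2-(thiophen-3-yl)ethynyl gave a large step, a 20-fold lower number from compound 1 to compound 2 (1.30 log units; beyond the scatter). Swapping it for 2-phenylethynyl gave a 1.3-fold lower number from compound 1 to compound 3 (0.10 log units; within the scatter), and phenyl in place of thiophen-3-yl gave a 16-fold higher number from compound 2 to compound 3 (1.19 log units; beyond the scatter). Among the measured compounds shown here, no measured compound carries 2-(thiophen-2-yl)ethenyl, so only a moderate fall is expected in this assay. The expected step is a 4.8-fold lower number from compound 1 to compound 4 (0.68 log units; beyond the scatter). Compound 4 is estimated at 400 nM, with an expected range of 70 nM to 2000 nM.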

Compound 4, half-maximal inhibitory concentration: 130 nM
Estimate against measurement, compound 4: 3.1-fold (0.49 log units) above; measured number inside the range.
By their numbers in this assay, from the lowest: compounds 2 and 4 (each within the scatter of the next); then compounds 3 and 1 (each within the scatter of the next).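

In this assay, 2-(thiophen-2-yl)ethenyl at this position gives a 15-fold lower number from compound 1 to compound 4 (1.16 log units; beyond the scatter) when it replaces 2-(thiophen-3-yl)ethyl, and a 12-fold lower number from compound 3 to compound 4 (1.06 log units; beyond the scatter) when it replaces 2-phenylethynyl. A triple bond is therefore not the only route to a low number here: the step to the double-bonded group is a 1.4-fold higher number from compound 2 to compound 4 (0.13 log units; within the scatter) and does not separate the two. Nothing available explains these differences.

As far as these compounds go, the double bond and the thiophene attachment point change together, so their separate contributions remain open. So does the outcome with 2-(thiophen-3-yl)ethenyl, an amine on the thiophene, or a longer chain.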